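From methyl to tert-butyl on the aromatic ring

The compounds below may be only part of what the source reports. "The series", "measured", "known", "first", "only" and "open" are said of these compounds alone.

Compound 1 `NC1=NC2(CCOCC2)N(OCCCOc2ccc(Cl)cc2)C(N)=N1` gives 690 nM
Compound 2 `NC1=NC2(CCOCC2)N(OCCCOc2ccc(F)cc2)C(N)=N1` gives 3280 nM
Compound 3 `Cc1ccc(OCCCON2C(N)=NC(N)=NC23CCOCC3)cc1` gives 2390 nM

All three numbers come from a functional assay on HCT-116 cells (Homo sapiens) for antiproliferative activity, read by MTT assay, with a stated time of 72 h (a higher number here means a weaker inhibitor, a lower number a stronger inhibitor), and the compounds differ in one group on an aromatic carbon: chloro in compound 1, fluoro in compound 2 and methyl in compound 3. Compound 3 belongs to the upper pair of numbers. The measured 1.4-fold lower number from compound 2 to compound 3 (0.14 log units; within the scatter) shows that this pair cannot be separated, while a 3.5-fold higher number from compound 1 to compound 3 (0.54 log units; beyond the scatter) sets compound 1 apart.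

Compound 4 `CC(C)(C)c1ccc(OCCCON2C(N)=NC(N)=NC23CCOCC3)cc1` has not yet been measured. It carries tert-butyl in place of methyl on an aromatic carbon, para to a large group (tert-butyl in place of methyl on an aromatic carbon). Going by the values given here, no measured compound has tert-butyl, so the measured steps bear on it only indirectly. The largest swap at this carbon, a 4.8-fold higher number from compound 1 to compound 2 (0.68 log units; beyond the scatter) as measured, was still modest. These steps give no firm direction for tert-butyl. Only a small step is therefore expected, leaning toward a lower number, as compound 3 at 2390 nM already lies in the upper pair. The estimated step in this assay is a 1.4-fold lower number from compound 3 to compound 4 (0.15 log units; within the scatter) at the middle of a wide range. Compound 4 is estimated at 1700 nM with 500 nM to 5000 nM as the expected range.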

Compound 4, half-maximal inhibitory concentration: 1610 nM
Estimate against measurement, compound 4: 1.1-fold (0.02 log units) above, within the range that was stated.
By their numbers in this assay, from the lowest: compound 1; then compounds 4, 3 and 2 (each within the scatter of the next, the first and the last beyond it).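

In this assay, tert-butyl brings four heavy atoms to this aromatic carbon where methyl has one, yet the two compounds cannot be told apart (a 1.5-fold lower number from compound 3 to compound 4 (0.17 log units; within the scatter)), so this large increase in group size leaves the result within the scatter. The earlier compounds shown here held only small groups, and compound 4 now shows that the position accepts a much larger one without the number moving outside the range those compounds span. Chloro still stands apart from every other group tested, including tert-butyl (a 2.3-fold higher number from compound 1 to compound 4 (0.37 log units; beyond the scatter)), while tert-butyl sits just beyond the scatter on the favourable side of fluoro (a 2.0-fold lower number from compound 2 to compound 4 (0.31 log units; beyond the scatter)), and nothing available here explains any of these differences.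

Still open, as far as these compounds go, is how an amine or a carboxylic acid on this carbon would compare with these four uncharged groups. It is also unknown whether bromo or trifluoromethyl in the same place would match compound 1 or fall with the other three.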